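Oxazolyl in Place of Phenyl on the Shared Core

The source may report more compounds than this note shows. Statements on the series, on what has been measured and on what is new or still open speak of the compounds shown alone.

Three measured compounds share a core and differ only by the group on one aromatic carbon. In a functional assay on aorta for antagonist activity at Alpha-1D adrenergic receptor (Rattus norvegicus) (a lower number here means tighter binding, a higher number weaker binding), compound 1 `CN(C)C(=O)c1cccnc1NCCCN1CCN(c2ccccc2)CC1` gives 15.9 nM. Compound 2 `CN(C)C(=O)c1cccnc1NCCCN1CCN(c2ccccc2OCC(F)(F)F)CC1` gives 15.9 nM in this assay. Compound 3 `CN(C)C(=O)c1cccnc1NCCCN1CCN(c2ccccc2-c2ccccc2)CC1` gives 63.1 nM, the highest of the three numbers. The steps of a 4.0-fold higher number from compound 1 to compound 3 (0.60 log units; beyond the scatter) and a 4.0-fold higher number from compound 2 to compound 3 (0.60 log units; beyond the scatter) both go up, whereas no change at the digits printed from compound 1 to compound 2 (within the scatter). Compound 4 `CN(C)C(=O)c1cccnc1NCCCN1CCN(c2ccccc2-c2ncco2)CC1` carries the change (1,3-oxazol-2-yl in place of phenyl on an aromatic carbon). Within the data shown here, those two steps into compound 3 bear on it: the phenyl is the group that accompanied the higher number, so exchanging it for a five-membered ring may undo part of that rise, though no measured step tests the oxazolyl itself. Compound 4 is therefore expected to show a 1.6-fold lower number from compound 3 to compound 4 (0.20 log units; within the scatter), with an estimated 40 nM and a range from 13 nM to 125 nM.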

Compound 4, dissociation constant: 25.1 nM
Beside the measured number, compound 4's estimate is 1.6-fold (0.20 log units) above it, within the range that was stated.
By their numbers in this assay, from the lowest: compounds 1, 2 and 4 (each within the scatter of the next); then compound 3.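

The exchange of phenyl for 1,3-oxazol-2-yl gives a 2.5-fold lower number from compound 3 to compound 4 (0.40 log units; beyond the scatter), so the rise seen with phenyl does not follow from having just any aromatic ring on this carbon, ortho to a large group. The oxazolyl also shows a 1.6-fold higher number from compound 1 to compound 4 (0.20 log units; within the scatter) and a 1.6-fold higher number from compound 2 to compound 4 (0.20 log units; within the scatter), which places compound 4 within the scatter of both compound 1 and compound 2. Nothing given here explains the difference between the two rings.

From the compounds shown here alone, it remains open whether the ring's nitrogen or its oxygen accounts for the step. Going by these compounds, how a pyridyl ring, a methoxy group or an amine on this carbon would compare also remains open.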